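This account rests on a few compounds, and the source may have more. Where it says the series, first, only, none or still open, it means among the compounds named here.

Working notes on the series in a functional assay on HL-60 cells (Homo sapiens) for antiproliferative activity, read by CellTiter-Glo, with a stated time of 72 h; a lower number here means a stronger inhibitor, a higher number a weaker inhibitor.

Compound 1 `CO[C@@H]1[C@H](N(C)c2ncc(-c3c[nH]c4ccc(Br)cc34)s2)C[C@H]2O[C@]1(C)n1c3ccccc3c3c4c(c5c6ccccc6n2c5c31)C(=O)NC4` carries a bromo group on its indole. In this assay compound 1 gives > 10000 nM, which is a limit of the assay and not a number. Compound 2 `COc1ccc2[nH]cc(-c3cnc(N(C)[C@@H]4C[C@H]5O[C@@](C)([C@@H]4OC)n4c6ccccc6c6c7c(c8c9ccccc9n5c8c64)C(=O)NC7)s3)c2c1` differs from it by methoxy in place of bromo on an aromatic carbon. In this assay compound 2 gives > 10000 nM, again only a limit. Compound 3 `CO[C@@H]1[C@H](N(C)c2ncc(-c3c[nH]c4ccc(Br)cc34)s2)C[C@H]2O[C@]1(C)n1c3ccccc3c3c4c(c5c6cc(Cl)ccc6n2c5c31)C(=O)NC4` differs from compound 1 by chloro in place of hydrogen on an aromatic carbon. In this assay compound 3 gives > 10000 nM, also a limit.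

The two steps from the measured pairs, a step that the two limits leave unreadable from compound 1 to compound 2 and a step that the two limits leave unreadable from compound 1 to compound 3, cannot be sized, because of the limit of > 10000 nM in this assay, at which 3 of the 3 values shown sit.

Compound 4 `COc1ccc2[nH]cc(-c3cnc(N(C)[C@@H]4C[C@H]5O[C@@](C)([C@@H]4OC)n4c6ccccc6c6c7c(c8c9cc(Cl)ccc9n5c8c64)C(=O)NC7)s3)c2c1` is not yet measured. It differs from compound 3 by methoxy in place of bromo on an aromatic carbon. The place line of this change reads the same, word for word, as for the change from compound 1 to compound 2, so it is the same change; the two cores differ by chloro in place of hydrogen on an aromatic carbon. The step is expected to be a number no higher from compound 3 to compound 4 (the limit leaves the size open), set beside a step that the two limits leave unreadable from compound 1 to compound 2, resting on the finding that compound 1, compound 2 and compound 3 all sit at the limit (the limit of > 10000 nM in this assay, at which 3 of the 3 values shown sit). Compound 4 is therefore estimated at 10000 nM, most likely again reported only as a limit.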

Compound 4, half-maximal inhibitory concentration: > 10000 nM
Compound 4: no number, only a limit (the forecaster's own chance of this, stated with the estimate: 85%); the middle value lies on the limit itself.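

In this assay compound 4 gives > 10000 nM, a limit and not a number. Within the data shown here, no step to compound 4 from compound 2 or compound 3 can be read, because all four compounds sit at the same limit: the limit of > 10000 nM in this assay, at which 4 of the 4 values shown sit. The compounds shown leave open whether either change, bromo to methoxy or hydrogen to chloro, alters activity in this assay.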